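Nitro in place of trifluoromethyl on the benzyl arm

This account rests on a few compounds, and the source may have more. Where it says the series, first, only, none or still open, it means among the compounds named here.

Measured compounds and their read-outs in a functional assay on MCF7 cells (Homo sapiens) for antiproliferative activity, tested at 1 uM; a higher number here means more inhibition at the concentration tested (going by the name of the read-out), a lower number less inhibition:
- compound 1, `Cc1ccc(CO/N=C/c2c(C)nn(C)c2Oc2ccc(Cl)cc2)cc1`, gives 30.7%
- compound 2, `CCOC(=O)c1ccc(CO/N=C/c2c(C)nn(C)c2Oc2ccc(Cl)cc2)cc1`, gives 33.9%
- compound 3, `Cc1nn(C)c(Oc2ccc(Cl)cc2)c1/C=N/OCc1ccc(C(F)(F)F)cc1`, gives 16.4%

Compound 3 stands lowest of the three numbers in this assay. Its nearest neighbour is compound 1, and the step of a number 14.3 percentage points lower from compound 1 to compound 3 (beyond the scatter) lies beyond the scatter; the step of a number 17.5 percentage points lower from compound 2 to compound 3 (beyond the scatter) is larger still. Within the data shown here, the only step not touching compound 3, a number 3.2 percentage points higher from compound 1 to compound 2 (within the scatter), stays within the scatter, so methyl and ethoxycarbonyl at this position give numbers that cannot be told apart, while trifluoromethyl sits clearly lower.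

Compound 4, `Cc1nn(C)c(Oc2ccc(Cl)cc2)c1/C=N/OCc1ccc([N+](=O)[O-])cc1`, has not yet been measured. It differs from compound 3 as follows: nitro in place of trifluoromethyl on an aromatic carbon. Among the measured compounds shown here, the two steps that bear on this position both show that exchanging trifluoromethyl for another group moves the number upward by a modest amount, and no measured step here exceeds a modest size. For the measured compounds named here, a modest rise in this assay is therefore expected, roughly back toward the level of compound 1, with wide uncertainty since nitro has no direct precedent among the measured compounds. The expected step is a number 8.6 percentage points higher from compound 3 to compound 4 (within the scatter). For compound 4 the estimate is 25%, with a range from 9% to 42%.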

Compound 4, a percentage reported as inhibition, at one concentration (the size of the read-out at that concentration, not a potency): 27.1%
The estimate for compound 4 lay 2.1 percentage points below the measured number; the range from low to high includes it.
By their numbers in this assay, from the lowest: compound 3; then compounds 4, 1 and 2 (each within the scatter of the next).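

In this assay, replacing trifluoromethyl with nitro gives a number 10.7 percentage points higher from compound 3 to compound 4 (beyond the scatter), so compound 3 now lies beyond the scatter from all three other compounds, and trifluoromethyl alone stands apart among the four groups at this position. Nitro cannot be told from the other two groups, since a number 3.6 percentage points lower from compound 1 to compound 4 (within the scatter) and a number 6.8 percentage points lower from compound 2 to compound 4 (within the scatter) both stay within the scatter, which places methyl, ethoxycarbonyl and nitro on one shared level even though they differ plainly as groups. Nothing available explains why trifluoromethyl alone separates from that level.

The compounds shown leave open whether a further group at this position, such as an amine, a carboxylic acid or a nitrile, would join that shared level, match compound 3 or move beyond both. They also leave open whether the separation of trifluoromethyl holds when another part of the shared core changes, and, as every number comes from a single tested concentration, how these compounds compare in potency.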